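The source may hold more compounds than are shown below. What is called first, only, known or untested is meant among the compounds shown, and "the series" means these compounds.

Three compounds of the series have been run in a functional assay on CHO cells with adenosine receptor A1 (Homo sapiens) as the target, read by cAMP accumulation and immunoassay, with a stated time of 6 min, tested at 0.1 uM; a higher number here means a weaker effect of the compound at the concentration tested, a lower number a stronger effect. Compound 1 `Nc1scc(CN2CCN(c3cccc4ccccc34)CC2)c1C(=O)c1ccc(Cl)cc1` gives 0%. Compound 2 `Nc1scc(CN2CCN(c3ccccc3F)CC2)c1C(=O)c1ccc(Cl)cc1` gives -1%. Compound 3 `Nc1scc(CN2CCN(c3cccc(F)c3F)CC2)c1C(=O)c1ccc(Cl)cc1` gives -5.2%, the lowest of the three numbers, though neither of the other two is separated from it by more than the scatter: the steps are a number 5.2 percentage points lower from compound 1 to compound 3 (within the scatter) and a number 4.2 percentage points lower from compound 2 to compound 3 (within the scatter). The remaining step, a number 1 percentage points lower from compound 1 to compound 2 (within the scatter), is of the same kind. Nothing in the set moves the activity read-out of this assay away from zero at the concentration tested.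

Compound 4 `Nc1scc(CN2CCN(c3ccc(F)c(Cl)c3)CC2)c1C(=O)c1ccc(Cl)cc1` has not yet been measured. It differs from compound 3 in one place: 3-chloro-4-fluorophenyl in place of 2,3-difluorophenyl on an amine nitrogen in a ring. Among the compounds with values here, the steps that bear on this change are the two that also exchanged the aryl group on the amine nitrogen in the ring, a number 1 percentage points lower from compound 1 to compound 2 (within the scatter) and a number 5.2 percentage points lower from compound 1 to compound 3 (within the scatter), and the single exchange of fluoro for hydrogen on an aromatic carbon, a number 4.2 percentage points lower from compound 2 to compound 3 (within the scatter); all three lie within the scatter. No step beyond the scatter is therefore expected in this assay; the expected step is a number 3.2 percentage points higher from compound 3 to compound 4 (within the scatter). Compound 4 is estimated at -2% in this assay, with a range from -14% to 10%.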

Compound 4, a percentage reported as activity, at one concentration (the size of the read-out at that concentration, not a potency): -21%
Compound 4: middle estimate off by 19 percentage points, on the high side, outside the stated range (below it).
By their numbers in this assay, from the lowest: compound 4; then compounds 3, 2 and 1 (each within the scatter of the next).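

Within the data shown here, the aryl group on the amine nitrogen in the ring now proves able to move the read-out in this assay, which the earlier compounds did not show: 3-chloro-4-fluorophenyl gives a number 15.8 percentage points lower from compound 3 to compound 4 (beyond the scatter), a number 20 percentage points lower from compound 2 to compound 4 (beyond the scatter) and a number 21 percentage points lower from compound 1 to compound 4 (beyond the scatter), each step towards a stronger effect at the concentration tested. The position is therefore not indifferent to the aryl group, even though naphthalen-1-yl, 2-fluorophenyl and 2,3-difluorophenyl remain within the scatter of one another, and the exchange of 2,3-difluorophenyl for 3-chloro-4-fluorophenyl leaves the counts of heavy atoms, hydrogen-bond donors and acceptors and the net charge unchanged. No measurement here accounts for the shift.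

The compounds shown leave open whether the step follows the chlorine alone or the chlorine and fluorine together, and whether a phenyl group carrying only chloro, or carrying bromo or methyl in its place, would go as far. A read-out at a single concentration also leaves the potency of compound 4 open.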